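A few compounds are considered here, and "the series" means these few. Any claim that something is new, unique, unknown or untested is made for them only; others in the source may bear on it.

Of the compounds shown here, three of a shared core have been tested in a functional assay on the whole organism (strain Wister albino) for inhibition, with Rattus norvegicus as the target, read by paw edema, with stated times of 1 h and 4 h, at a dose of 50 mg/kg by the intraperitoneal route; on this read-out lower numbers stand for less inhibition and higher numbers for more inhibition at the one dose given (going by the name of the read-out). Compound 1, `CCOC(=O)c1c(-c2ccc(F)cc2)cc(-c2ccccc2)nc1N1CCCCC1`, gives 76% in this assay. Compound 2, `CCOC(=O)c1c(-c2ccc(C)cc2)cc(-c2ccccc2)nc1N1CCCCC1`, gives 78%. Compound 3, `CCOC(=O)c1c(-c2ccc(F)cc2)cc(-c2ccccc2)nc1Nc1ccc(Cl)cc1`, gives 78.4%.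

Compound 2 differs from compound 1 in one place: methyl in place of fluoro on an aromatic carbon. The step that goes with this change is a number 2 percentage points higher from compound 1 to compound 2 (within the scatter). Compound 3 differs from compound 1 in another place, the one where the two cores part company: (4-chlorophenyl)amino in place of piperidin-1-yl on an aromatic carbon. The step here is a number 2.4 percentage points higher from compound 1 to compound 3 (within the scatter). The three numbers therefore sit together, and none of them can be called the highest.

Compound 4, `CCOC(=O)c1c(-c2ccc(C)cc2)cc(-c2ccccc2)nc1Nc1ccc(Cl)cc1`, has not yet been measured in this assay. It differs from compound 3 as follows: methyl in place of fluoro on an aromatic carbon. Within the data shown here, this is the same change as the one from compound 1 to compound 2, made on the core of compound 3 rather than that of compound 1. Because the earlier step was a number 2 percentage points higher from compound 1 to compound 2 (within the scatter), the step from compound 3 to compound 4 is expected to be small as well, a number 0.6 percentage points higher from compound 3 to compound 4 (within the scatter). On that basis compound 4 is estimated to give 79% in this assay, with the expected range running from 70% to 88%.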

Compound 4, a percentage reported as inhibition, in the whole organism at one dose (the size of the read-out at that dose, not a potency): 79.4%
For compound 4 the middle estimate is 0.4 percentage points below the measured one; low and high end bracket the measured number.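

In this assay, methyl in place of fluoro gives a number 1 percentage points higher from compound 3 to compound 4 (within the scatter), and this step does not differ from the one seen with the same change on the core of compound 1: the same change on two cores in this assay, a number 2 percentage points higher (within the scatter) from compound 1 to compound 2 and a number 1 percentage points higher (within the scatter) from compound 3 to compound 4, 1 percentage points apart, within the scatter of two such steps

The other change, (4-chlorophenyl)amino in place of piperidin-1-yl, gives a number 1.4 percentage points higher from compound 2 to compound 4 (within the scatter), and it likewise agrees with its earlier counterpart: the same change on two cores in this assay, a number 2.4 percentage points higher (within the scatter) from compound 1 to compound 3 and a number 1.4 percentage points higher (within the scatter) from compound 2 to compound 4, 1 percentage points apart, within the scatter of two such steps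

Every one of these steps lies within the scatter, so the agreement is one of small steps on two cores at a single dose; it does not show that either change has an effect of its own on inhibition, nor that a larger step would carry from one core to another in the same way.

The compounds shown all keep the ethyl ester and the unsubstituted phenyl group on the shared core, so it stays open whether a carboxylic acid or an amide in place of that ester would move the number beyond the scatter. As far as these compounds go, it is equally open whether a methoxy group or a nitrile in place of fluoro or methyl, or a morpholine in place of piperidin-1-yl, would do so, and whether such a step would then hold on both cores.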